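Series notes: from compound 2 to compound 3

A few compounds are considered here, and "the series" means these few. Any claim that something is new, unique, unknown or untested is made for them only; others in the source may bear on it.

Compound 2 `Cc1ccc(-c2ccc(S(=O)(=O)Nc3cccc(CO)c3)cc2)cc1` holds the lowest of the two numbers seen so far: in a functional assay on J774 cells (Mus musculus) for cytotoxicity, read by resazurin assay, with a stated time of 72 h (on this read-out higher numbers stand for weaker inhibition and lower numbers for stronger inhibition), compound 2 gives 1200 nM. Compound 1 `O=S(=O)(Nc1cccc(CO)c1)c1ccc(-c2ccc(Br)cc2)cc1` gives 2500 nM in this assay. Among the measured compounds shown here, the single step recorded, a 2.1-fold lower number from compound 1 to compound 2 (0.32 log units; beyond the scatter), is modest. Compound 3 `O=S(=O)(Nc1cccc(CO)c1)c1ccc(-c2ccccc2F)cc1` differs from compound 2 by 2-fluorophenyl in place of 4-methylphenyl on an aromatic carbon. For the measured compounds named here, no measured step covers this change; the step from compound 1 to compound 2 shows only that varying the group on that aromatic carbon moves the number modestly. For compound 3 a step of comparable size in this assay, direction uncertain, is expected: a 1.7-fold higher number from compound 2 to compound 3 (0.22 log units; within the scatter). Compound 3 is estimated at 2000 nM (range 800 nM to 5000 nM).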

Compound 3, half-maximal inhibitory concentration: 1300 nM
Compound 3: middle estimate off by 1.5-fold (0.19 log units), on the high side, and the stated range covers the measured number.
By their numbers in this assay, from the lowest: compounds 2, 3 and 1 (each within the scatter of the next, the first and the last beyond it).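

In this assay the change to 2-fluorophenyl gives a 1.1-fold higher number from compound 2 to compound 3 (0.03 log units; within the scatter) and a 1.9-fold lower number from compound 1 to compound 3 (0.28 log units; within the scatter) and neither step leaves the scatter. This aromatic carbon therefore carries 2-fluorophenyl as well as 4-methylphenyl with no separation in the number, something compound 1 and compound 2 alone could not show. Nothing available gives a reason for this result.

Still open, on these data alone, is how an unsubstituted phenyl or 4-fluorophenyl would compare on this carbon. Also open, as far as these compounds go, is whether a ring bearing an amine or a carboxylic acid would move the number further.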